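Bromine position on the hydroxyphenyl amide: compound 4

The source may report more compounds than this note shows. Statements on the series, on what has been measured and on what is new or still open speak of the compounds shown alone.

Compound 2 `O=C(Nc1ccc(Sc2nc3ccccc3s2)cc1)c1cccc(Br)c1O` is the starting point for the step under study. In an assay on isolated protein for inhibition of thiosulfate sulfurtransferase (Homo sapiens), with a stated time of 60 min, in the absence of a further agent (on this read-out lower numbers stand for stronger inhibition and higher numbers for weaker inhibition), compound 2 gives > 100000 nM, which is a limit of the assay and not a number. Compound 1 `O=C(Nc1ccc(Sc2nc3ccccc3s2)c(Cl)c1)c1cccc(Br)c1O` carries a chloro on an aromatic carbon of the shared core where compound 2 carries hydrogen. In this assay compound 1 gives > 100000 nM, again a limit. The step that the two limits leave unreadable from compound 1 to compound 2 is therefore not readable in size or direction. Compound 3 `COc1c(Br)cc(Br)cc1C(=O)Nc1ccc(Sc2nc3ccccc3s2)cc1` carries a methoxy and two bromines on the amide-side ring. In this assay compound 3 gives > 100000 nM, a limit as well. Within the data shown here, all three values shown thus rest on (the limit of > 100000 nM in this assay, at which 3 of the 3 values shown sit), so nothing so far has returned a number.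

Compound 4 `O=C(Nc1ccc(Sc2nc3ccccc3s2)cc1)c1cc(Br)ccc1O` differs from compound 2 by 5-bromo-2-hydroxyphenyl in place of 3-bromo-2-hydroxyphenyl on a carbonyl carbon. Among the measured compounds shown here, no measured step concerns a move of the bromine on that ring; the only measured step, from compound 1 to compound 2, is unreadable. With every value shown sitting at the limit, compound 4 is expected to stay there too, with an estimated step of a number no higher from compound 2 to compound 4 (the limit leaves the size open) of no readable size. Compound 4 is estimated at 100000 nM, with a range from 30000 nM to 300000 nM.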

Compound 4, half-maximal inhibitory concentration: > 100000 nM
Compound 4 ended at the assay's limit (the forecaster's own chance of this, stated with the estimate: 85%); the middle value lies on the limit itself.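

In this assay compound 4 gives > 100000 nM, a limit and not a number. The step between compound 2 and compound 4 therefore cannot be read in size or direction: the limit of > 100000 nM in this assay, at which 4 of the 4 values shown sit.

The compounds shown leave open which change to this series, if any, would return a number in this assay.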